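The source may report more compounds than this note shows. Statements on the series, on what has been measured and on what is new or still open speak of the compounds shown alone.

The compounds share one core and differ in the groups on oxygens on an aromatic ring: compound 1 is `CCCCCCCC(=O)Oc1cc(C(=O)C2=C3OC(C)(C)[C@@H](CC=C(C)C)C[C@@]34C[C@@H](CC=C(C)C)C(C)(C)[C@H]3CCC(C)(C)O[C@]34OC2=O)ccc1O`, compound 2 is `CC(C)=CC[C@H]1C[C@]23C[C@@H](CC=C(C)C)C(C)(C)[C@H]4CCC(C)(C)O[C@]42OC(=O)C(C(=O)c2ccc(O)c(O)c2)=C3OC1(C)C`, compound 3 is `CCC(=O)Oc1ccc(C(=O)C2=C3OC(C)(C)[C@@H](CC=C(C)C)C[C@@]34C[C@@H](CC=C(C)C)C(C)(C)[C@H]3CCC(C)(C)O[C@]34OC2=O)cc1OC(=O)CC` and compound 4 is `CCC(=O)Oc1cc(C(=O)C2=C3OC(C)(C)[C@@H](CC=C(C)C)C[C@@]34C[C@@H](CC=C(C)C)C(C)(C)[C@H]3CCC(C)(C)O[C@]34OC2=O)ccc1O`. Among the compounds with values here, in a functional assay on MCF7 cells (Homo sapiens) for antiproliferative activity, read by MTT assay, with a stated time of 72 h (a lower number here means a stronger inhibitor, a higher number a weaker inhibitor), compound 2 gives 13500 nM, the only true number so far. Compound 1 reads > 20000 nM, which is a limit of the assay and not a number. Compound 3 reads > 20000 nM, and this is also a limit. Compound 3 therefore stands at the limit of > 20000 nM in this assay, at which 2 of the 3 values shown sit.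

The move to compound 4 is hydrogen in place of propanoyl on an oxygen on an aromatic ring, or propanoyloxy to hydroxy. One measured step is of the same kind, with hydrogen in place of heptylcarbonyl on an oxygen on an aromatic ring: an at least 1.4-fold lower number from compound 1 to compound 2 (0.17 log units; that floor lies within the scatter). That step starts from a limit and its floor lies within the scatter, so it is only a weak guide. A modest change towards a lower number is expected in this assay, estimated as an at least 1.3-fold lower number from compound 3 to compound 4 (0.12 log units; that floor lies within the scatter), and the assay may again return only a limit. For compound 4 the estimate is 15000 nM, with an expected range from 8000 nM to 20000 nM.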

Compound 4, half-maximal inhibitory concentration: > 20000 nM
Compound 4 gave a limit, no number; the forecaster's own chance of this, stated with the estimate: 45%; middle value at least 1.3-fold (0.12 log units) from the limit.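

Compound 4 shows that a propanoyl on this one oxygen on the aromatic ring is enough to leave no true number in this assay, just as the heptylcarbonyl on the same oxygen in compound 1 did, so the longer chain is not needed for that outcome: the limit of > 20000 nM in this assay, at which 3 of the 4 values shown sit. Putting propanoyl in place of hydrogen on this oxygen gives an at least 1.4-fold higher number from compound 2 to compound 4 (0.17 log units; that floor lies within the scatter), so this change points the same way as the earlier step from a limit, but its size is not established and its floor does not clear the usual variation. The steps from compound 3 to compound 4 and from compound 1 to compound 4 join two limits and cannot be read.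

As far as these compounds go, how far compound 1, compound 3 and compound 4 lie past the limit, and whether they differ from one another, stays open. Within the data shown here, also open is whether a different group on this oxygen, such as a methyl ether or a carbamate, would give a true number in this assay, and how that number would stand against the one for compound 2.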